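A few compounds are considered here, and "the series" means these few. Any claim that something is new, unique, unknown or untested is made for them only; others in the source may bear on it.

Working notes on the series. Compound 1 `CN(C)[C@H]1C[C@H](c2c[nH]c3ccc(C(N)=O)cc32)C1` stands at the lower of the two numbers measured in an assay on CHO-K1 cells for binding affinity to 5-hydroxytryptamine receptor 1B (Homo sapiens) (a lower number here means a stronger inhibitor, a higher number a weaker inhibitor), where compound 1 gives 44.7 nM. Within the data shown here, compound 2 `Cc1nc(Cc2ccc3[nH]cc([C@H]4C[C@H](N(C)C)C4)c3c2)n[nH]1` gives 3890 nM in this assay; the single step in hand, an 87-fold higher number from compound 1 to compound 2 (1.94 log units; beyond the scatter), shows that the group on this aromatic carbon is not interchangeable without cost. Compound 3 `CN(C)[C@H]1C[C@H](c2c[nH]c3ccc(CC(N)=O)cc32)C1` carries a smaller change than that: carbamoylmethyl in place of carbamoyl on an aromatic carbon. Among the measured compounds shown here, no measured step tests this homologation directly; the step from compound 1 to compound 2 bears on it only as a sign that the position responds strongly to what sits there, though the group entering compound 3 keeps the same donor and acceptor count. Expected for compound 3 is a moderate loss, a 3.4-fold higher number from compound 1 to compound 3 (0.53 log units; beyond the scatter), clearly smaller than the step to compound 2 because an 87-fold higher number from compound 1 to compound 2 (1.94 log units; beyond the scatter) involved a far larger group. The estimate for compound 3 in this assay is 150 nM, with a range of 40 nM to 600 nM.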

Compound 3, half-maximal inhibitory concentration: 1350 nM
For compound 3 the middle estimate is 9.0-fold (0.95 log units) below the measured one; the measured number lies above the stated range.
By their numbers in this assay, from the lowest: compound 1; then compound 3; then compound 2.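

Carbamoylmethyl in place of carbamoyl in this assay gives a 30-fold higher number from compound 1 to compound 3 (1.48 log units; beyond the scatter) even though the hydrogen-bond donor and acceptor counts stay the same, so one added chain carbon is enough to produce a large step at this aromatic carbon. Carbamoyl in place of 5-methyl-1H-1,2,4-triazol-3-yl on that saturated chain carbon gives only a 2.9-fold lower number from compound 2 to compound 3 (0.46 log units; beyond the scatter) and thus recovers little, so among these three compounds the greater part of the difference from compound 1 goes with the chain carbon and not with the group it carries. No evidence on the cause of either step is available here.

The compounds shown leave open whether a nitrile or an N-methyl amide placed directly on the aromatic carbon would stay close to compound 1. They also leave open how a longer chain bearing the carbamoyl would read.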